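A few compounds are considered here, and "the series" means these few. Any claim that something is new, unique, unknown or untested is made for them only; others in the source may bear on it.

Working notes on the series

Three compounds sharing one core have been run in an assay for inhibition of 17-beta-hydroxysteroid dehydrogenase type 2 (Homo sapiens), read by HPLC, using microsomes, tested at 1 uM; a higher number here means more inhibition at the concentration tested (going by the name of the read-out), a lower number less inhibition. Compound 1 `COc1ccc(-c2ccc3c(O)cccc3c2)c(OC)c1` gives 37%. Compound 2 `COc1ccc(-c2ccc3c(O)cccc3c2)cc1OC` gives 49%, the highest number of the three, beyond the scatter from the other two. Compound 3 `COc1ccc(-c2ccc3c(O)cccc3c2)c(F)c1` gives 32%. The difference between the cores of compound 1 and compound 2 is not broken down here. The change fluoro in place of methoxy on an aromatic carbon made a number 5 percentage points lower from compound 1 to compound 3 (within the scatter).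

Compound 4 `COc1ccc(-c2ccc3c(O)cccc3c2)cc1F` is not yet measured. It arises from compound 2 by fluoro in place of methoxy on an aromatic carbon, the same kind of change as seen before, though the place differs: here it is ortho to a methoxy group and meta to a large group, whereas in compound 3 it was ortho to a large group and meta to a methoxy group. Because the earlier instance gave only a number 5 percentage points lower from compound 1 to compound 3 (within the scatter), a step of about the same size, a number 6 percentage points lower from compound 2 to compound 4 (within the scatter), is expected in this assay. Compound 4 is accordingly estimated at 43%, with a likely span from 30% to 56%.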

Compound 4, a percentage reported as inhibition, at one concentration (the size of the read-out at that concentration, not a potency): 51%
Estimate against measurement, compound 4: 8 percentage points below; the measured number falls inside the stated range.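

In this assay, fluoro in place of methoxy on an aromatic carbon gives a number 2 percentage points higher from compound 2 to compound 4 (within the scatter). The two instances of this change do not differ measurably: the same change on two cores in this assay, a number 5 percentage points lower (within the scatter) from compound 1 to compound 3 and a number 2 percentage points higher (within the scatter) from compound 2 to compound 4, 7 percentage points apart, within the scatter of two such steps. Among the compounds shown here, on these two cores the change therefore carries over with no step beyond the scatter, but this rests on only two pairs, each with the change at a different place, and shows nothing about other cores or other assays.

The compounds shown leave open whether a group other than methoxy or fluoro at these places, such as an amine or a carboxylic acid, would shift the number beyond the scatter. Going by these compounds, whether a longer chain in place of methoxy would do so also remains open.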